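This account rests on a few compounds, and the source may have more. Where it says the series, first, only, none or still open, it means among the compounds named here.

Series notes. The shared core carries a urea linking an aryl group to a phenylethyl group; compound 1 `CCCCCCc1ccc(NC(=O)N[C@@H](C)c2ccccc2)cc1` bears a hexyl on the aromatic carbon, compound 2 `CCOC(=O)c1ccc(NC(=O)N[C@@H](C)c2ccccc2)cc1` an ethoxycarbonyl in that place. In an ADME assay on the whole organism with Oryza sativa as the target, tested at 0.1 uM (on this read-out lower numbers stand for a stronger effect and higher numbers for a weaker effect at the one concentration tested), compound 1 gives 99%; in this assay compound 2 gives 99%. Among the measured compounds shown here, the one step measured so far, no change at the digits printed from compound 1 to compound 2 (within the scatter), shows that swapping hexyl for ethoxycarbonyl left the read-out where it was. Compound 2 thus stands level with compound 1 at the digits shown, and nothing in the two measured values separates them.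

Compound 3 `CC(=O)c1ccc(NC(=O)N[C@@H](C)c2ccccc2)cc1` is the next member, not yet measured. Its change from compound 2 is methyl in place of ethoxy on a carbonyl carbon, read one bond further out as ethoxycarbonyl to acetyl. For the measured compounds named here, the only step that bears on it is the one from compound 1 to compound 2, which stayed within the scatter, and that step altered the same aromatic substituent. Therefore no step beyond the scatter is expected for compound 3 in this assay, the expected step being a number 2 percentage points lower from compound 2 to compound 3 (within the scatter). The value for compound 3 is estimated at 97%, with a range from 85% to 100%.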

Compound 3, a percentage reported as activity, at one concentration (the size of the read-out at that concentration, not a potency): 99%
Compound 3: middle estimate off by 2 percentage points, on the low side, and the stated range covers the measured number.
By their numbers in this assay, from the lowest: compounds 1, 2 and 3 (each within the scatter of the next).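

In this assay the step read as ethoxycarbonyl to acetyl gives no change at the digits printed from compound 2 to compound 3 (within the scatter) and thus extends the earlier finding from a swap of the whole aromatic substituent to a change made on the carbonyl carbon itself, where methyl takes the place of ethoxy. The direct comparison of the hexyl and acetyl groups gives no change at the digits printed from compound 1 to compound 3 (within the scatter) and closes the set: hexyl, ethoxycarbonyl and acetyl on this aromatic carbon all stay within the scatter of one another, with compound 3 at 99% on the side of the scale that stands for a weak effect at the one concentration tested. No accompanying measurement bears on why the read-out holds level across these changes.

The compounds shown leave open whether an amine or a carboxylic acid on this aromatic carbon would give a step beyond the scatter. They also leave open whether a change to the phenylethyl group, such as a longer chain in place of its methyl, would move the read-out at all.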